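The source may hold more compounds than are shown below. What is called first, only, known or untested is meant among the compounds shown, and "the series" means these compounds.

Measured compounds and their values in a functional assay on HepG2 cells (Homo sapiens) for antiproliferative activity, read by spectrophotometry, with a stated time of 2 days; on this read-out higher numbers stand for weaker inhibition of growth and lower numbers for stronger inhibition of growth:
compound 1 `COc1cc(Nc2ncc(C(F)(F)F)c(N3Cc4cccc(N(C)S(C)(=O)=O)c4C3)n2)cc(OC)c1`, 1800 nM;
compound 2 `CC(=O)N1CCN(c2ccc(Nc3ncc(C(F)(F)F)c(N4Cc5cccc(N(C)S(C)(=O)=O)c5C4)n3)cc2)CC1`, 1400 nM;
compound 3 `CN(c1cccc2c1CN(c1nc(Nc3cc(Cl)cc(C(F)(F)F)c3)ncc1C(F)(F)F)C2)S(C)(=O)=O`, 9900 nM.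

Among these three numbers compound 1 stands second highest. Compound 2 lies within the scatter of it, so the two cannot be told apart, whereas compound 3 sits clearly higher: a 5.5-fold higher number from compound 1 to compound 3 (0.74 log units; beyond the scatter). Compound 4 `Cc1ccc(Nc2ncc(C(F)(F)F)c(N3Cc4cccc(N(C)S(C)(=O)=O)c4C3)n2)c(C)c1` differs from compound 1 in one place: 2,4-dimethylphenyl in place of 3,5-dimethoxyphenyl on a nitrogen on an aromatic ring. Among the measured compounds shown here, the only measured step at this position is the one just given, in which another substituted phenyl replaced the 3,5-dimethoxyphenyl and the number rose modestly. A similar rise, beyond the scatter but not large, is therefore expected here. Compound 4 is estimated at 3500 nM, with a range from 1500 nM to 9000 nM. That estimate corresponds to an expected step of a 1.9-fold higher number from compound 1 to compound 4 (0.29 log units; within the scatter).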

Compound 4, concentration for 50% growth inhibition: 19100 nM
Compound 4: middle estimate off by 5.5-fold (0.74 log units), on the low side; the measured number lies above the stated range.
By their numbers in this assay, from the lowest: compounds 2 and 1 (each within the scatter of the next); then compounds 3 and 4 (each within the scatter of the next).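

This position tolerates change less well than the earlier step suggested: in this assay, 2,4-dimethylphenyl gives a large step (an 11-fold higher number from compound 1 to compound 4 (1.03 log units; beyond the scatter)). Compound 4 cannot be told apart from compound 3 (a 1.9-fold higher number from compound 3 to compound 4 (0.29 log units; within the scatter)), so two different replacements of 3,5-dimethoxyphenyl both give numbers higher than compound 1, beyond the scatter. Nothing measured here explains the size of this step.

The compounds shown leave open how a plain phenyl or a phenyl carrying a single methoxy group would compare with compound 1. They also leave open what a phenyl carrying a carboxylic acid would do at this position.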